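This account rests on a few compounds, and the source may have more. Where it says the series, first, only, none or still open, it means among the compounds named here.

Measured compounds:
compound 1, `COc1ccc(/C=C\c2cc(OC)c(OC)c(OC)c2)cc1NC(=O)[C@H](CO)NC(=O)[C@H](CCCNC(=N)N)NC(=O)[C@H](CCCNC(=N)N)NC(=O)c1ccccc1`, 23.1 nM in an ADME assay on Huh-7 cells (Homo sapiens) for cytotoxicity, with a stated time of 72 h; a lower number here means that less compound is tolerated, a higher number that more compound is tolerated
compound 2, `COc1ccc(/C=C\c2cc(OC)c(OC)c(OC)c2)cc1NC(=O)CN`, 26.9 nM in this assay

The account follows compound 1 into an untested relative. Compound 1 gives the lower of the two numbers, but its gap to compound 2 is within the scatter, so the two measured compounds are read as giving the same result in this assay.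

Compound 3, `COc1ccc(/C=C\c2cc(OC)c(OC)c(OC)c2)cc1NC(=O)[C@H](C)NC(=O)[C@H](CCCNC(=N)N)NC(=O)[C@H](CCCNC(=N)N)NC(=O)c1ccccc1`, differs from compound 1 in one place: hydrogen in place of hydroxy on a saturated chain carbon, two bonds along the chain from an amide-type nitrogen and a carbonyl carbon. Among the compounds with values here, no pair of measured compounds shows what this change does, so no step can be read off for it. With the two measured numbers lying so close together, and the change being the loss of a single oxygen from a side chain, the step from compound 1 to compound 3 is expected to be small, a 1.1-fold lower number from compound 1 to compound 3 (0.02 log units; within the scatter), and not beyond the scatter in either direction. Compound 3 is therefore estimated at 22 nM in this assay, with a range from 10 nM to 50 nM.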

Compound 3, half-maximal cytotoxic concentration: 191 nM
Compound 3: the middle estimate sits 8.7-fold (0.94 log units) below what was measured, and the stated range ends below it.
By their numbers in this assay, from the lowest: compounds 1 and 2 (each within the scatter of the next); then compound 3.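

In this assay, the change from hydroxymethyl to methyl gives an 8.3-fold higher number from compound 1 to compound 3 (0.92 log units; beyond the scatter), so more compound is tolerated once this one oxygen is gone. The earlier pair could not show this: compound 1 and compound 2 differ in more than one place, and their closeness said nothing about this position on a saturated chain carbon, two bonds along the chain from an amide-type nitrogen and a carbonyl carbon. Nothing available explains why the loss of the hydroxy group has this effect.

The compounds shown leave open whether the step belongs to the hydroxy group alone, since an amine, a carboxylic acid or a longer chain on this carbon does not appear among them. Within the data shown here, whether the same change would give a similar step on another core also stays open, as this single pair is the only reading of it.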